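Ester to ketone in a weakly active triazole series

This account rests on a few compounds, and the source may have more. Where it says the series, first, only, none or still open, it means among the compounds named here.

Working notes on the series. Compound 1 `C=C(C)[C@@H]1CC=C(Cn2cc(COc3ccccc3C3NC(=O)NC(C)=C3C(=O)OCC)nn2)CC1` carries an ethyl ester on the shared core. Compound 2 `C=C(C)[C@@H]1CC=C(Cn2cc(COc3cc(C4NC(=O)NC(C)=C4C(=O)OCC)ccc3OC)nn2)CC1` has the same ester with a methoxy-bearing aryl ether. In a functional assay on U-251 cells (Homo sapiens) for inhibition, read by sulforhodamine B assay, with a stated time of 48 h (on this read-out higher numbers stand for weaker inhibition of growth and lower numbers for stronger inhibition of growth), compound 1 reaches only the assay limit, > 100000 nM, so no number is known for it. In this assay compound 2 gives 98100 nM. Compound 1 stands at the limit, as noted in the limit of > 100000 nM in this assay, at which 1 of the 2 values shown sits. Going by the values given here, no step between measured compounds is available.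

Compound 3 `C=C(C)[C@@H]1CC=C(Cn2cc(COc3ccccc3C3NC(=O)NC(C)=C3C(C)=O)nn2)CC1` differs from compound 1 by methyl in place of ethoxy on a carbonyl carbon. Among the compounds with values here, no measured pair informs this change, so no size or direction is grounded in the data. For compound 3 the expected step of a number no higher from compound 1 to compound 3 (the limit leaves the size open) is none beyond the scatter. In this assay compound 3 is therefore estimated at 100000 nM, with a range from 40000 nM to 250000 nM, and a limit read-out is expected to be likely.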

Compound 3, concentration for total growth inhibition: 30200 nM
Compound 3: the middle estimate sits 3.3-fold (0.52 log units) above what was measured; the measured number lies below the stated range.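

Going by these compounds alone, at the carbonyl carbon whose other neighbour is the double-bonded ring carbon, ethoxycarbonyl to acetyl is the first change that can be read as a step: in this assay it gives an at least 3.3-fold lower number from compound 1 to compound 3 (0.51 log units; beyond the scatter). The ethyl ester is therefore not required for the growth inhibition read here, and this position bears on the read-out. For compound 1 the value > 100000 nM is a limit, so the printed step gives only the smallest size the change can have: the limit of > 100000 nM in this assay, at which 1 of the 3 values shown sits.

From the compounds shown here alone, whether the same change would carry over to the methoxy-bearing aryl ether of compound 2 stays open. The compounds shown also leave open how a carboxylic acid, a primary amide or a longer chain on the carbonyl carbon would read at this position.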